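This account rests on a few compounds, and the source may have more. Where it says the series, first, only, none or still open, it means among the compounds named here.

Working notes on the series.

Compound 1, `CC(=O)Nc1ccc(Nc2nccc(-c3cccnc3)n2)cc1`, and compound 2, `Cc1cc(-c2ccco2)nc(Nc2ccc(N(C)C)cc2)n1`, have been measured in a functional assay for inhibition, with Homo sapiens as the target; on this read-out higher numbers stand for weaker inhibition and lower numbers for stronger inhibition. Compound 1 gives 3600 nM. Compound 2 gives 5900 nM. The two numbers lie within the usual scatter of each other, so compound 1 stands level with compound 2 on what has been measured; neither number sets it apart. Going by the values given here, no step between measured compounds is available, as the two share only part of their structure and differ in several places at once.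

Compound 3, `Oc1ccc(Nc2nccc(-c3cccnc3)n2)cc1`, is the next one to be measured in this assay. It differs from compound 1 in one place: hydroxy in place of acetamido on an aromatic carbon.

Among the compounds with values here, the shared core of compound 1 and compound 3 is untouched by this change, and there is no measured pair that shows what such a swap does. With nothing to go on beyond the two numbers in hand, the expectation for compound 3 is a step from compound 1 of a 1.1-fold higher number from compound 1 to compound 3 (0.05 log units; within the scatter), that is, none beyond the scatter in either direction. Compound 3 is therefore estimated at 4000 nM, with a range from 1200 nM to 13000 nM.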

Compound 3, half-maximal inhibitory concentration: 5100 nM
For compound 3 the middle estimate is 1.3-fold (0.11 log units) below the measured one; low and high end bracket the measured number.
By their numbers in this assay, from the lowest: compounds 1, 3 and 2 (each within the scatter of the next).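

Going by these compounds alone, this is the first single-place step, and it gives a direct reading at this position, on an aromatic carbon of a six-membered aromatic ring of carbon only, para to a large group: in this assay, hydroxy in place of acetamido gives a 1.4-fold higher number from compound 1 to compound 3 (0.15 log units; within the scatter). The group that leaves has 4 heavy atoms and a double bond outside aromatic rings, the group that enters has 1 heavy atom, and each carries 1 hydrogen-bond donor and 1 hydrogen-bond acceptor, so at this position the acetamido can give way to the much smaller hydroxy with the two compounds standing level. Nothing measured beyond these numbers bears on why the two compounds stand level.

The compounds shown leave open what a methoxy, an amine, a carboxylic acid or a longer chain would do at this position, and whether any of them would move the number beyond the scatter. They also leave open what single-place swaps elsewhere on the shared core would do.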